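From Methoxy to Nitro: Estimating Compound 4

This account rests on a few compounds, and the source may have more. Where it says the series, first, only, none or still open, it means among the compounds named here.

Compound 1 `Nc1scc(CN2CCN(c3ccc(Cl)cc3Cl)CC2)c1C(=O)c1ccc(Cl)cc1`: -74%
Compound 2 `Nc1scc(CN2CCN(c3ccc(Cl)cc3F)CC2)c1C(=O)c1ccc(Cl)cc1`: -81%
Compound 3 `COc1ccc(N2CCN(Cc3csc(N)c3C(=O)c3ccc(Cl)cc3)CC2)cc1`: -52%

All three share one core and differ in the aromatic group on the amine nitrogen in a ring. In a functional assay on CHO cells with adenosine receptor A1 (Homo sapiens) as the target, read by cAMP accumulation and immunoassay, with a stated time of 6 min, tested at 10 uM (on this read-out lower numbers stand for a stronger effect and higher numbers for a weaker effect at the one concentration tested), compound 3 shows the highest number of the three, a weaker effect: the steps of a number 22 percentage points higher from compound 1 to compound 3 (beyond the scatter) and a number 29 percentage points higher from compound 2 to compound 3 (beyond the scatter) both lie beyond the scatter, while a number 7 percentage points lower from compound 1 to compound 2 (within the scatter) does not.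

Compound 4 `Nc1scc(CN2CCN(c3ccc([N+](=O)[O-])cc3)CC2)c1C(=O)c1ccc(Cl)cc1` arises from compound 3 by nitro in place of methoxy on an aromatic carbon. Among the measured compounds shown here, no measured step swaps one small group for another on that aromatic group; the two steps beyond the scatter exchange the whole aromatic group, and the one within it touches a different aromatic carbon. So nothing here predicts a shift beyond the scatter in either direction. Compound 4 is therefore expected near -58%, in a range from -85% to -30%, which means an expected step of a number 6 percentage points lower from compound 3 to compound 4 (within the scatter).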

Compound 4, a percentage reported as activity, at one concentration (the size of the read-out at that concentration, not a potency): -17%
Beside the measured number, compound 4's estimate is 41 percentage points below it, and the stated range ends below it.
By their numbers in this assay, from the lowest: compounds 2 and 1 (each within the scatter of the next); then compound 3; then compound 4.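

At this aromatic carbon, para to a large group, exchanging one small group for another is enough to move the read-out in this assay: nitro in place of methoxy gives a number 35 percentage points higher from compound 3 to compound 4 (beyond the scatter), without replacing the whole aromatic group. Against the two halogen-bearing aromatic groups the gaps are wider, at a number 64 percentage points higher from compound 2 to compound 4 (beyond the scatter) and a number 57 percentage points higher from compound 1 to compound 4 (beyond the scatter), leaving compound 4 with the weakest effect of the four. Nothing available here explains this shift. Going by these compounds, whether an amine or a nitrile on the same carbon would weaken the effect as nitro does remains open.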